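A few compounds are considered here, and "the series" means these few. Any claim that something is new, unique, unknown or untested is made for them only; others in the source may bear on it.

Of the compounds shown here, three have been tested in an ADME assay on HepG2 2.2.15 cells (Homo sapiens) for cytotoxicity, read by MTT assay; a higher number here means that more compound is tolerated, a lower number that less compound is tolerated. Compound 1 `CC(=O)c1ccc(OC(=O)/C=C/c2cccc(F)c2)cc1` gives > 3100000 nM, which is a limit of the assay and not a number. Compound 2 `CC(=O)c1ccc(OC(=O)c2ccccc2)cc1` gives > 3340000 nM, and this too is a limit. Within the data shown here, compound 3 `COc1cc(C(=O)Oc2ccc(C(C)=O)cc2)cc(OC)c1OC` gives 1210000 nM, the only true number among the three. Compound 2 therefore stands with a limit alone, and one of the other two compounds does the same.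

Compound 4 `CC(=O)c1ccc(OC(=O)c2ccco2)cc1` has not yet been measured. It carries furan-2-yl in place of phenyl on a carbonyl carbon. Among the measured compounds shown here, no two measured compounds differ in one place only, so the data give no direct size for a change of this kind. In this assay, the expectation is therefore for no step beyond the scatter, or for a small fall at most. The estimated step is an at least 1.1-fold lower number from compound 2 to compound 4 (0.04 log units; that floor lies within the scatter). The low end of the expected range leans on compound 3 at 1210000 nM, which carries a different group on the same carbonyl carbon. A result reported only as a limit is about as likely as a number. Compound 4 is estimated at 3000000 nM, with an expected range from 1200000 nM to 4500000 nM.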

Compound 4, half-maximal cytotoxic concentration: > 4040000 nM
Compound 4 gave a limit, no number (the forecaster's own chance of this, stated with the estimate: 55%); middle value at least 1.3-fold (0.12 log units) from the limit.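

Compound 2 and compound 4 both stand as limits of the assay and not as numbers, so no step can be read for furan-2-yl in place of phenyl on a carbonyl carbon in this assay. The compounds shown leave open whether this change alters how much compound is tolerated, and in which direction.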